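The source may hold more compounds than are shown below. What is called first, only, known or untested is meant among the compounds shown, and "the series" means these compounds.

The measured compounds in an in vitro assay on BTI-TN-5B1-4 cells for inhibition of Amine oxidase [flavin-containing] B (Homo sapiens); a higher number here means a weaker inhibitor, a lower number a stronger inhibitor:

Compound 1 `COc1ccc(-c2cc(=S)c3ccc(OC)cc3o2)cc1` gives 3340 nM in this assay.
Compound 2 `Cc1ccc(C2CC(=O)c3ccc(C)cc3O2)cc1` gives 500 nM in this assay.
Compound 3 `COc1ccc(C2CC(=O)c3ccc(C)cc3O2)cc1` gives 3350 nM in this assay.

Compound 3 has the highest number of the three, but its value and that of compound 1 lie within the scatter of each other, so the two cannot be told apart. Only compound 2 stands clearly apart, as the step of a 6.7-fold higher number from compound 2 to compound 3 (0.83 log units; beyond the scatter) shows; that step, too, was a methoxy in place of a methyl on an aromatic carbon, though at another site in the molecule.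

Compound 4 `COc1ccc(C2CC(=O)c3ccc(OC)cc3O2)cc1` differs from compound 3 in one place: methoxy in place of methyl on an aromatic carbon. Among the compounds with values here, the single measured step of the same kind, a 6.7-fold higher number from compound 2 to compound 3 (0.83 log units; beyond the scatter), pointed toward a higher number. It concerned another site, so it bears on the new step only loosely. Compound 1, which carries two methoxy groups, sits at a similar number as compound 3, which suggests the second methoxy need not move the number much. Compound 4 is therefore expected to give 5000 nM in this assay, within a range of 2000 nM to 15000 nM, and the expected step of a 1.5-fold higher number from compound 3 to compound 4 (0.17 log units; within the scatter) is modest, toward a higher number or none beyond the scatter.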

Compound 4, half-maximal inhibitory concentration: 7180 nM
Compound 4: the middle estimate sits 1.4-fold (0.16 log units) below what was measured; the range from low to high includes it.
By their numbers in this assay, from the lowest: compound 2; then compounds 1 and 3 (each within the scatter of the next); then compound 4.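

In this assay, the step of a 2.1-fold higher number from compound 3 to compound 4 (0.33 log units; beyond the scatter) shows that methoxy in place of methyl on this aromatic carbon, meta to a fused ring and para to a fused ring, gives a change beyond the scatter. The earlier step of a 6.7-fold higher number from compound 2 to compound 3 (0.83 log units; beyond the scatter) concerned another site, so the same exchange has now moved the number in the same direction at two sites, and neither of these two steps goes against that pattern. No measurement at hand gives a reason for the higher number at this position.

Going by these compounds, it remains open what an amine or a longer chain such as ethoxy would do on this aromatic carbon, and whether such groups would also give a higher number than methyl. On these data alone, it is also open whether the exchange here would give a step of the same size with methyl rather than methoxy at the other site, since these two steps each describe a single setting of the rest of the molecule.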